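One More Chloro on Compound 2

The compounds below may be only part of what the source reports. "The series", "measured", "known", "first", "only" and "open" are said of these compounds alone.

Compound 1 `Cc1ccc(Oc2ccc3nc(COc4cccc(C(=O)O)c4)n(C)c3n2)cc1` gives 1310 nM
Compound 2 `Cn1c(COc2cccc(C(=O)O)c2)nc2ccc(Oc3ccc(Cl)cn3)cc21` gives 161 nM

In an ADME assay on the whole organism (strain Zucker) for pharmacokinetics, with Rattus norvegicus as the target, with a stated time of 14 days, at a dose of 3 mg/kg by the oral route (on this read-out lower numbers stand for lower exposure and higher numbers for higher exposure at the dose given), compound 2 stands lower of the two with 161 nM and compound 1 reaches 1310 nM so the gap lies beyond the usual scatter. The two compounds differ in more than one place, so this gap does not show what any single change does.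

Compound 3 `Cn1c(COc2cccc(C(=O)O)c2)nc2ccc(Oc3ncc(Cl)cc3Cl)cc21` is compound 2 with one change chloro in place of hydrogen on an aromatic carbon in which chloro takes the place of hydrogen on an aromatic carbon and 5-chloropyridin-2-yl becomes 3,5-dichloropyridin-2-yl. Within the data shown here, no measured pair shows this change, so neither direction is favoured and no shift beyond the scatter is expected. The estimated size is a 1.1-fold higher number from compound 2 to compound 3 (0.02 log units; within the scatter) and that stays within the scatter. For compound 3 the estimated value is 170 nM with an expected range of 60 nM to 480 nM in repeated measurements.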

Compound 3, maximal plasma concentration: 293 nM
Compound 3: the middle estimate sits 1.7-fold (0.24 log units) below what was measured, within the range that was stated.
By their numbers in this assay, from the lowest: compounds 2 and 3 (each within the scatter of the next); then compound 1.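

In this assay, among these compounds, chloro in place of hydrogen on this aromatic carbon gives a 1.8-fold higher number from compound 2 to compound 3 (0.26 log units; within the scatter), the first comparison in this set in which only one place differs. On this read-out, compound 2 and compound 3 cannot be told apart, so a second chloro can sit on this carbon, ortho to a large group and meta to the existing chloro group, with no effect that stands out from repeated measurements. No measurement shown here gives a reason for this result.

As far as these compounds go, whether an amine or a methoxy group on this same carbon would also stay within the scatter of compound 2 remains open. From the compounds shown here alone, compound 1 differs from compound 2 in more than one place, so it also remains open which of those differences goes with the higher number of compound 1.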